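Ring-opened side-chain amine on a chloroquinoline core

This account rests on a few compounds, and the source may have more. Where it says the series, first, only, none or still open, it means among the compounds named here.

Among the compounds with values here, compound 2 `C[C@@H](CCCN1CCCCC1)Nc1ccnc2cc(Cl)ccc12` gives 150000 nM in an assay for binding affinity, read by spectrophotometry (a higher number here means a weaker inhibitor, a lower number a stronger inhibitor), the highest of the two numbers so far; compound 1 `C[C@H](CCCN1CCCCC1)Nc1ccnc2cc(Cl)ccc12` gives 130000 nM, and the step of a 1.2-fold higher number from compound 1 to compound 2 (0.06 log units; within the scatter) rests on (the fact that compounds 1 and 2 differ only in the configuration as drawn). Compound 3 `CCN(C)CCC[C@H](C)Nc1ccnc2cc(Cl)ccc12` differs from compound 2 by ethyl(methyl)amino in place of piperidin-1-yl on a saturated chain carbon, four bonds along the chain from a nitrogen on an aromatic ring. Within the data shown here, no measured step covers this change; the only one known concerns configuration and stayed within the scatter. For the ring-to-chain exchange the expected step is no change at the digits printed from compound 2 to compound 3 (within the scatter), with no direction beyond the scatter. Compound 3 is therefore estimated at 150000 nM, within 50000 nM to 450000 nM in this assay.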

Compound 3, half-maximal inhibitory concentration: 150000 nM
Beside the measured number, compound 3's estimate shows no gap at the digits printed, within the range that was stated.
By their numbers in this assay, from the lowest: compounds 1, 2 and 3 (each within the scatter of the next).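

In this assay, ethyl(methyl)amino in place of piperidin-1-yl gives no change at the digits printed from compound 2 to compound 3 (within the scatter). Within the data shown here, the earlier compounds differed only in configuration, so this is the first reading on the group itself: on this saturated chain carbon, the six-membered ring can give way to an open-chain amine without a step beyond the scatter. Nothing known here bears on why the number holds.

The compounds shown leave open whether any group at this position moves the number beyond the scatter, such as a carboxylic acid or a morpholin-4-yl group. They also leave open what a longer chain would do.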